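Working notes: 5-chloropyridin-2-yl to 5-methylpyridin-2-yl

This account rests on a few compounds, and the source may have more. Where it says the series, first, only, none or still open, it means among the compounds named here.

Measured so far in an ADME assay for permeability, using PAMPA, with a stated time of 4 h; a lower number here means that the compound crosses the layer more slowly, a higher number that the compound crosses the layer faster
- compound 1 `Cc1cc(C)cc(Oc2ccc3nc(COc4cccc(C(=O)O)c4)n(C)c3n2)c1` gives 17.4 10^-6 cm/s
- compound 2 `Cn1c(COc2cccc(C(=O)O)c2)nc2ccc(Oc3ccc4c(c3)OCC4)nc21` gives 9.1 10^-6 cm/s
- compound 3 `Cn1c(COc2cccc(C(=O)O)c2)nc2ccc(Oc3ccc(Cl)cn3)cc21` gives 16.2 10^-6 cm/s

Compound 3 lies within the scatter of both compound 1 and compound 2, so these three values do not separate. Compound 4 `Cc1ccc(Oc2ccc3nc(COc4cccc(C(=O)O)c4)n(C)c3c2)nc1` differs from compound 3 by methyl in place of chloro on an aromatic carbon. Among the compounds with values here, no measured step makes this exchange. The one available, a 1.9-fold lower number from compound 1 to compound 2 (0.28 log units; within the scatter), changes another group, on an oxygen on an aromatic ring. Within the data shown here, with that as the only guide, no change beyond the scatter is expected in this assay, and no direction is favoured. The expected outcome is a 1.1-fold lower number from compound 3 to compound 4 (0.03 log units; within the scatter) as the estimated step. Compound 4 is estimated at 15 10^-6 cm/s, with an expected range of 8 10^-6 cm/s to 27 10^-6 cm/s.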

Compound 4, apparent permeability: 4.8 10^-6 cm/s
Estimate against measurement, compound 4: 3.1-fold (0.49 log units) above; measured number outside the range, below it.
By their numbers in this assay, from the lowest: compounds 4, 2, 3 and 1 (each within the scatter of the next, the first and the last beyond it).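

In this assay, within the data shown here, methyl in place of chloro on an aromatic carbon para to a large group gives a 3.4-fold lower number from compound 3 to compound 4 (0.53 log units; beyond the scatter), the only step here beyond the scatter. Among these compounds, this shows that exchanging one heavy atom at this position, with hydrogen-bond donor and acceptor counts unchanged, can move the number beyond the scatter, which the earlier compounds did not show. No measurement available bears on the cause of this step. Going by these compounds, how a nitrile or an amine on this carbon would read remains open, as does whether the same exchange gives a similar step on another core.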